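Aryl group change in the antiproliferative series

The compounds below may be only part of what the source reports. "The series", "measured", "known", "first", "only" and "open" are said of these compounds alone.

Among the measured compounds shown here, in a functional assay on KB cells (Homo sapiens) for antiproliferative activity, read by sulforhodamine B assay, with a stated time of 3 days (a higher number here means that more compound is needed for the effect, a lower number that less compound is needed), compound 2 `CCC1=C(O)c2c(oc(-c3ccc(OC)c(C)c3)cc2=O)C(CC)(CC)C1=O` gives 28.5 uM, the only actual number so far. Compound 1 `CCC1=C(O)c2c(oc(-c3ccccc3)cc2=O)C(CC)(CC)C1=O`, which carries phenyl on the shared core, reads > 236 uM, and this is a limit of the assay.

Compound 3 `CCC1=C(O)c2c(oc(-c3cc(C)ccc3C)cc2=O)C(CC)(CC)C1=O` has 2,5-dimethylphenyl in place of the 4-methoxy-3-methylphenyl of compound 2, on the same aromatic carbon next to the ring oxygen: 2,5-dimethylphenyl in place of 4-methoxy-3-methylphenyl on an aromatic carbon.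

For the measured compounds named here, one measured step bears on this change: an at least 8.2-fold lower number from compound 1 to compound 2 (0.91 log units; beyond the scatter). It shows that replacing phenyl with a substituted aryl group can matter in this assay, but it does not separate the contributions of the methyl and methoxy groups. Nor does it cover a 2,5-dimethylphenyl group. Compound 3 keeps a substituted aryl group, so a return to the limit seen for compound 1 is possible but not the expected outcome. A step beyond the scatter is not expected, though the estimate leans towards a higher number: a 1.4-fold higher number from compound 2 to compound 3 (0.15 log units; within the scatter). For compound 3 the expected value is 40 uM, with an estimated range of 12 uM to 160 uM.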

Compound 3, concentration for half-maximal effect: 14.5 uM
The estimate for compound 3 lay 2.8-fold (0.44 log units) above the measured number; measured number inside the range.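

In this assay, a second substituted aryl group on the aromatic carbon next to the ring oxygen also moves well away from phenyl, with an at least 16-fold lower number from compound 1 to compound 3 (1.21 log units; beyond the scatter), so the gain over phenyl is not tied to 4-methoxy-3-methylphenyl alone and persists with no methoxy group on the aryl ring. Exchanging 4-methoxy-3-methylphenyl for 2,5-dimethylphenyl gives a 2.0-fold lower number from compound 2 to compound 3 (0.29 log units; within the scatter), which means that the two aryl groups cannot be told apart in this assay, even though only the first of them carries a hydrogen-bond acceptor. Compound 1 still provides only a limit and not a number, so both steps from it are bounds rather than exact sizes: the limit of > 236 uM in this assay, at which 1 of the 3 values shown sits.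

As far as these compounds go, compound 2 and compound 3 each carry two substituents on the aryl ring, so it remains open whether a single methyl group or a single methoxy group on the phenyl would be enough for the gain over phenyl. Also open, from the compounds shown here alone, is what an amine, a carboxylic acid or a chlorine atom on this aryl ring would do to the number in this assay.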